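A Larger Alkyl Group on the Shared Core

The source may hold more compounds than are shown below. What is called first, only, known or untested is meant among the compounds shown, and "the series" means these compounds.

Compound 1 `Oc1ccccc1CNc1ccc(-c2ccc(F)cc2)cc1`: 3860 nM
Compound 2 `Cc1ccc(-c2ccc(NCc3ccccc3O)cc2)cc1`: 3790 nM

In a functional assay on Jurkat cells (Homo sapiens) for activation, with a stated time of 24 h (on this read-out higher numbers stand for an effect only at larger amounts of compound and lower numbers for an effect already at smaller amounts), compound 2 gives the lower of the two numbers shown, yet its gap to compound 1 is within the scatter, so the two are not ordered. Compound 3 `CC(C)(C)c1ccc(-c2ccc(NCc3ccccc3O)cc2)cc1` differs from compound 2 by tert-butyl in place of methyl on an aromatic carbon. Going by the values given here, the only measured step, a 1.0-fold lower number from compound 1 to compound 2 (0.01 log units; within the scatter), swapped one small group for another at this same place without effect; no step enlarges a group there. Compound 3 is therefore expected to change little, with a 1.1-fold lower number from compound 2 to compound 3 (0.03 log units; within the scatter) as the estimate, giving 3500 nM (range 1200 nM to 10000 nM).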

Compound 3, half-maximal effective concentration: "not active" (no number reported)
Compound 3: no number reported, so the estimate cannot be set against anything.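

In this assay, going by these compounds alone, compound 3 is reported only as "not active", without a number, so no step from compound 2 to compound 3 can be read. Nothing available bears on this result. The compounds shown leave open whether any group larger than methyl at this place keeps a measurable effect.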